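Replacing trifluoromethyl with amino on compound 2

The compounds below may be only part of what the source reports. "The series", "measured", "known", "first", "only" and "open" are said of these compounds alone.

In a functional assay on PC-3 cells (Homo sapiens) for antiproliferative activity, read by MTT assay, with a stated time of 48 h (on this read-out higher numbers stand for weaker inhibition and lower numbers for stronger inhibition), compound 1 `COc1cc(N(Cc2ccccc2)C(=O)CSc2nc3ccccc3s2)cc(OC)c1OC` gives 54100 nM. Compound 2 `COc1ccc(CN(C(=O)CSc2nc3ccccc3s2)c2cc(OC)c(OC)c(OC)c2)cc1C(F)(F)F` gives > 80000 nM, which is a limit of the assay and not a number; it stands at the limit of > 80000 nM in this assay, at which 1 of the 2 values shown sits. Going by the values given here, the only measured step is an at least 1.4-fold higher number from compound 1 to compound 2 (0.16 log units; that floor lies within the scatter). That step involves no amino group, so it offers no measured size for the next change. Compound 3 `COc1ccc(CN(C(=O)CSc2nc3ccccc3s2)c2cc(OC)c(OC)c(OC)c2)cc1N` carries amino in place of trifluoromethyl on an aromatic carbon, ortho to a methoxy group (amino in place of trifluoromethyl on an aromatic carbon). With compound 1 at 54100 nM as the only numeric anchor, a reading in that region is expected. A lower number for compound 3 than for compound 2 is the likelier direction in this assay. The expected step is an at least 2.2-fold lower number from compound 2 to compound 3 (0.35 log units; beyond the scatter), though its size remains uncertain. For compound 3 the estimate is 35000 nM, with an expected range of 8000 nM to 80000 nM.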

Compound 3, half-maximal inhibitory concentration: 7510 nM
Compound 3: middle estimate off by 4.7-fold (0.67 log units), on the high side; measured number below the stated range.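

In this assay, the position ortho to a methoxy group proves sensitive to the group it carries: amino in place of trifluoromethyl gives an at least 10-fold lower number from compound 2 to compound 3 (1.02 log units; beyond the scatter). That size is only a floor, as the value of compound 2 is a limit of the assay and not a number: the limit of > 80000 nM in this assay, at which 1 of the 3 values shown sits. Against plain phenyl, 3-amino-4-methoxyphenyl gives a 7.2-fold lower number from compound 1 to compound 3 (0.86 log units; beyond the scatter), so substitution on this ring can lower the number beyond the scatter, which the earlier step, an at least 1.4-fold higher number from compound 1 to compound 2 (0.16 log units; that floor lies within the scatter), did not show.

The compounds shown do not separate the share of the amino group from that of the methoxy group beside which it stands in the printed ortho relation, nor do they say what the amino group contributes through its hydrogens. A methylamino group, an acetamide or a hydroxyl at this position would test how specific the amino result is.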